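Amide-bound aryl swap in a bis-nitrobenzylidene series

A few compounds are considered here, and "the series" means these few. Any claim that something is new, unique, unknown or untested is made for them only; others in the source may bear on it.

The series shares one core carrying two nitrophenyl groups, with a varied aryl amide at the far end. Compound 1 `COc1ccc(NC(=O)/C=C/C(=O)N2C/C(=C\c3ccc([N+](=O)[O-])cc3)C(=O)/C(=C/c3ccc([N+](=O)[O-])cc3)C2)cc1` gives 940 nM in a functional assay on Molt4/C8 cells (Homo sapiens) for cytotoxicity; a higher number here means a weaker inhibitor, a lower number a stronger inhibitor. Compound 2 `O=C(/C=C/C(=O)N1C/C(=C\c2ccc([N+](=O)[O-])cc2)C(=O)/C(=C/c2ccc([N+](=O)[O-])cc2)C1)Nc1ccc(Cl)c(Cl)c1` gives 600 nM in this assay, the lowest of the two numbers shown, though the step of a 1.6-fold lower number from compound 1 to compound 2 (0.19 log units; within the scatter) keeps compound 2 within the scatter of compound 1. Compound 3 `CC(=O)c1ccc(NC(=O)/C=C/C(=O)N2C/C(=C\c3ccc([N+](=O)[O-])cc3)C(=O)/C(=C/c3ccc([N+](=O)[O-])cc3)C2)cc1` differs from compound 2 in one place: 4-acetylphenyl in place of 3,4-dichlorophenyl on an amide-type nitrogen. Among the measured compounds shown here, the only comparable step is the same aryl replacement from compound 1 to compound 2, which was a 1.6-fold lower number from compound 1 to compound 2 (0.19 log units; within the scatter); on that basis no change beyond the scatter is expected in this assay for compound 3, and the step is estimated as a 1.3-fold higher number from compound 2 to compound 3 (0.12 log units; within the scatter). Compound 3 is therefore expected to give about 800 nM in this assay, within a range of 400 nM to 1600 nM.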

Compound 3, half-maximal inhibitory concentration: 390 nM
For compound 3 the middle estimate is 2.1-fold (0.31 log units) above the measured one; measured number below the stated range.
By their numbers in this assay, from the lowest: compounds 3, 2 and 1 (each within the scatter of the next, the first and the last beyond it).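

In this assay, among the compounds shown here, the change of acetyl for methoxy on an aromatic carbon gives the first step beyond the scatter, a 2.4-fold lower number from compound 1 to compound 3 (0.38 log units; beyond the scatter), though it is modest. By contrast, a 1.5-fold lower number from compound 2 to compound 3 (0.19 log units; within the scatter) does not separate 4-acetylphenyl from 3,4-dichlorophenyl on the amide-type nitrogen, so compound 2 remains within the scatter of both compound 1 and compound 3, and the aryl groups shown are resolved only at the two ends of this small set. No data at hand bear on the origin of the step from methoxy to acetyl.

From the compounds shown here alone, whether an amine, a carboxylic acid or a nitrile on the same aromatic carbon would extend this step remains open. A longer acyl chain in place of acetyl is equally unresolved, as is whether the step holds outside this assay.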